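A Fluoro-to-Trifluoromethyl Swap Under a Cytotoxicity Limit

A few compounds are considered here, and "the series" means these few. Any claim that something is new, unique, unknown or untested is made for them only; others in the source may bear on it.

Three related compounds were tested in an ADME assay on HepG2 cells (Homo sapiens) for cytotoxicity, read by CellTiter-Glo and resazurin assay, with a stated time of 72 h; on this read-out higher numbers stand for an effect only at larger amounts of compound and lower numbers for an effect already at smaller amounts. Among the compounds with values here, compound 1 `CC(C)N(Cc1cccc(OCCCCCC(=O)O)c1)C(=O)c1ccc(-c2cccc(F)c2)cc1` is the first of them. In this assay compound 1 gives > 26000 nM, which is a limit of the assay rather than a number. Compound 2 `CC(C)N(Cc1cccc(OCCCCCC(=O)O)c1)C(=O)c1ccc(-c2cccc(C(F)(F)F)c2)cc1` differs from compound 1 by trifluoromethyl in place of fluoro on an aromatic carbon. In this assay compound 2 gives > 26000 nM, again a limit. This change gives a step that the two limits leave unreadable from compound 1 to compound 2. Compound 3 `CCOC(=O)CCCCCOc1cccc(CN(C(=O)c2ccc(-c3cccc(F)c3)cc2)C(C)C)c1` keeps the fluoro group, but its core differs from the core of compound 1 by ethyl in place of hydrogen on an oxygen next to a carbonyl group. In this assay compound 3 gives > 26000 nM, also a limit. That change gives a step that the two limits leave unreadable from compound 1 to compound 3. Compound 4 `CCOC(=O)CCCCCOc1cccc(CN(C(=O)c2ccc(-c3cccc(C(F)(F)F)c3)cc2)C(C)C)c1`, not yet measured, differs from compound 3 by trifluoromethyl in place of fluoro on an aromatic carbon, the same change already seen from compound 1 to compound 2 and found twice among these compounds. For compound 4 the expected step is a step that the limit leaves unreadable from compound 3 to compound 4, and this expectation rests on (the limit of > 26000 nM in this assay, at which 3 of the 3 values shown sit). Compound 4 is therefore estimated to give 30000 nM, with a likely range from 20000 nM to 60000 nM.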

Compound 4, half-maximal effective concentration: > 26000 nM
Compound 4: a limit, no number; the forecaster's own chance of this, stated with the estimate: 85%; the middle value is on the limit's open side.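

In this assay compound 4 gives > 26000 nM, which is a limit and not a number, so neither its step from compound 3 nor its step from compound 2 can be read: the limit of > 26000 nM in this assay, at which 4 of the 4 values shown sit. The compounds shown leave open at what concentration any of the four would affect these cells, and whether the trifluoromethyl or ethyl change alters that concentration.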